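This account rests on a few compounds, and the source may have more. Where it says the series, first, only, none or still open, it means among the compounds named here.

Among the measured compounds shown here, compound 3, `O=C(NO)c1ccc(/C=C/c2ccnc(-c3cccc(CO)c3)c2)cc1`, gives 1740 nM in a functional assay on MGC-803 cells (Homo sapiens) for antiproliferative activity, read by CellTiter-Glo, with a stated time of 72 h (a lower number here means a stronger inhibitor, a higher number a weaker inhibitor), which is the lowest of the three numbers so far, although compound 1, `O=C(NO)c1ccc(/C=C/c2ccnc(-c3cc(F)ccc3O)c2)cc1`, with 1920 nM sits within the scatter of it, as the step of a 1.1-fold lower number from compound 1 to compound 3 (0.04 log units; within the scatter) shows. Compound 2, `COc1ccccc1-c1cc(/C=C/c2ccc(C(=O)NO)cc2)ccn1`, gives 6350 nM and stands apart, with a 3.6-fold lower number from compound 2 to compound 3 (0.56 log units; beyond the scatter).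

The next compound is compound 4, `COc1ccc(-c2cc(/C=C/c3ccc(C(=O)NO)cc3)ccn2)cc1`. Compared with compound 3 it carries 4-methoxyphenyl in place of 3-(hydroxymethyl)phenyl on an aromatic carbon.

For the measured compounds named here, only one measured step involves a methoxyphenyl group: a 3.6-fold lower number from compound 2 to compound 3 (0.56 log units; beyond the scatter), where the group that leaves here came in for a 2-methoxyphenyl. Compound 4 instead carries a 4-methoxyphenyl, so that step bears on it only loosely, and the other step, a 3.3-fold higher number from compound 1 to compound 2 (0.52 log units; beyond the scatter), says nothing about the 4-methoxyphenyl either. The data give no direct guide, so the expectation is cautious: a methoxyphenyl group with no hydrogen-bond donor is expected to cost somewhat in potency relative to compound 3, but less than the full step seen for compound 2, so a modest rise in the number of compound 4 is expected, a 2.0-fold higher number from compound 3 to compound 4 (0.30 log units; within the scatter). Compound 4 is therefore estimated at 3500 nM, with a range from 1500 nM to 8000 nM.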

Compound 4, half-maximal inhibitory concentration: 3510 nM
The estimate for compound 4 lay 1.0-fold (0.00 log units) below the measured number; the measured number falls inside the stated range.
By their numbers in this assay, from the lowest: compounds 3, 1, 4 and 2 (each within the scatter of the next, the first and the last beyond it).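

In this assay, replacing 3-(hydroxymethyl)phenyl with 4-methoxyphenyl, a group with the same heavy-atom count but no hydrogen-bond donor, gives a 2.0-fold higher number from compound 3 to compound 4 (0.30 log units; within the scatter), so at this position, next to the ring nitrogen, losing that donor produces no change that can be told from the scatter. The other two new steps are also within the scatter, a 1.8-fold lower number from compound 2 to compound 4 (0.26 log units; within the scatter) and a 1.8-fold higher number from compound 1 to compound 4 (0.26 log units; within the scatter), so neither moving the methoxy group from the 2-methoxyphenyl to the 4-methoxyphenyl arrangement nor replacing 5-fluoro-2-hydroxyphenyl has a resolved effect, and compound 4 sits within the scatter of compounds that themselves lie beyond it from compound 2. No measurement at hand explains these numbers.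

Because the step from compound 3 to compound 4 alters the group and its place on the phenyl ring together, the compounds shown cannot separate those two changes. They also leave open whether a phenyl ring carrying an amine, a carboxylic acid or a longer chain at this position would give a number beyond the scatter of compound 3.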